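Naphthyl in place of cyanophenyl on the piperazine arm

The source may hold more compounds than are shown below. What is called first, only, known or untested is meant among the compounds shown, and "the series" means these compounds.

Two compounds carry numbers in an assay on COS-7 cells for binding affinity to 5-hydroxytryptamine receptor 1D (Homo sapiens); on this read-out higher numbers stand for weaker inhibition and lower numbers for stronger inhibition. Compound 1 `COc1ccc(NC(=O)c2ccc(-c3ccc(C4=NC(C)ON4)cc3C)cc2)cc1N1CCN(C)CC1` gives 0.74 nM in this assay. Compound 2 `CN1CCN(c2cccc3ccc(OCC(=O)N4CCN(c5ccccc5C#N)CC4)cc23)CC1` gives 0.51 nM in this assay, a value that sits within the scatter of the value of compound 1, so the two are not distinguished. They differ in more than one place, and their values show only that both lie at the low end of the range.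

Compound 3 `CN1CCN(c2cccc3ccc(OCC(=O)N4CCN(c5cccc6ccccc56)CC4)cc23)CC1` has not yet been measured. It differs from compound 2 in a single place: naphthalen-1-yl in place of 2-cyanophenyl on an amine nitrogen in a ring. Within the data shown here, no measured pair shows this change, so nothing in the data fixes its size. The aryl group on the ring nitrogen is kept, while the nitrile is gone. A small step from compound 2 to compound 3 is expected, a 2.0-fold higher number from compound 2 to compound 3 (0.29 log units; within the scatter), toward a somewhat higher number or none beyond the scatter. Compound 3 is estimated at 1 nM, with a range from 0.3 nM to 4 nM.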

Compound 3, inhibition constant: 0.88 nM
Beside the measured number, compound 3's estimate is 1.1-fold (0.06 log units) above it; the range from low to high includes it.
By their numbers in this assay, from the lowest: compounds 2, 1 and 3 (each within the scatter of the next).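

In this assay, naphthalen-1-yl in place of 2-cyanophenyl on the amine nitrogen in a ring gives a 1.7-fold higher number from compound 2 to compound 3 (0.24 log units; within the scatter) and so does not distinguish the two compounds. For this pair, a nitrile on the aryl group is therefore not required for a value at the low end of the range, and an aryl group with two six-membered aromatic rings of carbon only fits there as well as one with a single ring. No evidence shown bears on why the two values lie so close.

The compounds shown leave open whether a plain phenyl, or a phenyl carrying a methoxy group or a chlorine in place of the nitrile, would give a similar value. They also leave open whether any aromatic ring is needed on this nitrogen, as a cyclohexyl or a methyl there would test.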